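A few compounds are considered here, and "the series" means these few. Any claim that something is new, unique, unknown or untested is made for them only; others in the source may bear on it.

Measured compounds:
- compound 1 `O=C(c1ccc(Cl)cc1)N1CCN(c2nc(=O)c3cc(C(F)(F)F)cc([N+](=O)[O-])c3s2)CC1`: in an ADME assay on Vero cells (Chlorocebus sabaeus) for cytotoxicity, read by MTT assay, with a stated time of 72 h (a higher number here means that more compound is tolerated, a lower number that less compound is tolerated), compound 1 gives > 125000 nM, which is a limit of the assay.
- compound 2 `CC1COC2(CCN(c3nc(=O)c4cc(C(F)(F)F)cc([N+](=O)[O-])c4s3)CC2)O1`: compound 2 gives > 125000 nM, again a limit.
- compound 3 `CCC(C)C(=O)N1CCN(c2nc(=O)c3cc(C(F)(F)F)cc([N+](=O)[O-])c3s2)CC1`: compound 3 gives > 125000 nM, also a limit.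

Compound 3 therefore stands at the limit of > 125000 nM in this assay, at which 3 of the 3 values shown sit, with nothing to separate it from compound 1 or compound 2. Among the measured compounds shown here, the one step that touches it, a step that the two limits leave unreadable from compound 1 to compound 3, cannot be read because both ends are limits.

Compound 4 `CCC(=O)N1CCN(c2nc(=O)c3cc(C(F)(F)F)cc([N+](=O)[O-])c3s2)CC1` carries the change (hydrogen in place of ethyl on a saturated chain carbon bound to a carbonyl carbon and a saturated chain carbon). For the measured compounds named here, no measured step bears on this change, and the only step is unreadable, so no shift beyond the scatter in this assay is expected. Compound 4 is estimated at 150000 nM (range 80000 nM to 300000 nM), most likely reported again as a limit, the expected step being a step that the limit leaves unreadable from compound 3 to compound 4.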

Compound 4, half-maximal cytotoxic concentration: > 125000 nM
Compound 4 ended at the assay's limit; the forecaster's own chance of this, stated with the estimate: 85%; the middle value does not contradict the limit.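

In this assay compound 4 also sits at a limit, so no step from compound 1 or compound 3 to compound 4 can be read: the limit of > 125000 nM in this assay, at which 4 of the 4 values shown sit.

On these data alone, whether compound 1, compound 3 and compound 4 differ at all in tolerated concentration stays open.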